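The source may report more compounds than this note shows. Statements on the series, on what has been measured and on what is new or still open speak of the compounds shown alone.

Compound 2 `CS(=O)(=O)c1cncc(-c2ccn3nc(N)nc3c2)c1` and compound 1 `CCN(CC)S(=O)(=O)c1cncc(-c2ccn3nc(N)nc3c2)c1` share one core and differ only in the group on the sulfonyl sulfur. In an assay on isolated protein for inhibition of phosphatidylinositol 4,5-bisphosphate 3-kinase catalytic subunit beta isoform (Homo sapiens) (a higher number here means a weaker inhibitor, a lower number a stronger inhibitor), compound 2 gives 39800000 nM; compound 1 gives 25100000 nM, and the two numbers lie within the usual scatter, as a 1.6-fold higher number from compound 1 to compound 2 (0.20 log units; within the scatter) shows. Compound 3 `Nc1nc2cc(-c3cncc(S(=O)(=O)Nc4ccccc4)c3)ccn2n1` carries anilino in place of methyl on a sulfonyl sulfur. For the measured compounds named here, the only step that bears on this change, swapping the group on the same sulfonyl sulfur, stayed within the scatter, so no step beyond the scatter is expected in this assay. For compound 3 the expected value is 30000000 nM, between 8000000 nM and 100000000 nM, an estimated step of a 1.3-fold lower number from compound 2 to compound 3 (0.12 log units; within the scatter).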

Compound 3, half-maximal inhibitory concentration: 31600000 nM
For compound 3 the middle estimate is 1.1-fold (0.02 log units) below the measured one; low and high end bracket the measured number.
By their numbers in this assay, from the lowest: compounds 1, 3 and 2 (each within the scatter of the next).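

Anilino brings a six-membered aromatic ring and a hydrogen-bond donor to the sulfonyl sulfur, yet in this assay the swap from methyl gives a 1.3-fold lower number from compound 2 to compound 3 (0.10 log units; within the scatter) and the swap from diethylamino gives a 1.3-fold higher number from compound 1 to compound 3 (0.10 log units; within the scatter). Methyl, diethylamino and anilino therefore all read alike within the scatter at this place, so even this larger ring-bearing group produces no readable step. Nothing measured here offers an explanation for this flat result. On these data alone, whether a carboxylic acid, a basic amine such as piperazine or a longer chain on the sulfonyl sulfur would shift the number stays open.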